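The compounds below may be only part of what the source reports. "The series", "measured", "known", "first", "only" and "open" are said of these compounds alone.

Measured so far in a functional assay on ZR-75-1 cells (Homo sapiens) for inhibition, read by sulforhodamine B assay; on this read-out higher numbers stand for weaker inhibition of growth and lower numbers for stronger inhibition of growth:
- compound 1 `c1ccc(-c2ccc(-c3ccc(-c4nc5ccccc5[nH]4)cc3)cc2)cc1`: 100000 nM
- compound 2 `FC(F)(F)c1ccc(-c2ccc(-c3ccc(-c4nc5ccccc5[nH]4)cc3)cc2)cc1`: 48300 nM
- compound 3 `Clc1cccc(-c2ccc(-c3ccc(-c4nc5ccccc5[nH]4)cc3)cc2)c1`: 41200 nM

Compound 1 has the highest number of the three, and both other compounds lie beyond the scatter from it. Compound 4 `Oc1cccc2[nH]c(-c3ccc(-c4ccc(-c5ccccc5)cc4)cc3)nc12` differs from compound 1 by hydroxy in place of hydrogen on an aromatic carbon. The nearest measured changes are also replacements of hydrogen on an aromatic carbon, though on a different ring and with different groups. These are a 2.1-fold lower number from compound 1 to compound 2 (0.32 log units; beyond the scatter) and a 2.4-fold lower number from compound 1 to compound 3 (0.39 log units; beyond the scatter), both modest. The gap between compounds 2 and 3 is small: a 1.2-fold lower number from compound 2 to compound 3 (0.07 log units; within the scatter). Among the measured compounds shown here, no hydroxy compound has been measured, so the guide is loose. A modest lowering is expected, estimated as a 2.9-fold lower number from compound 1 to compound 4 (0.46 log units; beyond the scatter). The estimate for compound 4 is 35000 nM, with an expected range of 8000 nM to 100000 nM.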

Compound 4, concentration for 50% growth inhibition: 35600 nM
Compound 4: the middle estimate sits 1.0-fold (0.01 log units) below what was measured; the range from low to high includes it.
By their numbers in this assay, from the lowest: compounds 4, 3 and 2 (each within the scatter of the next); then compound 1.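

In this assay, hydroxy in place of hydrogen on an aromatic carbon of the fused system, ortho to a fused ring, gives a 2.8-fold lower number from compound 1 to compound 4 (0.45 log units; beyond the scatter) and so a modest change beyond the scatter. This extends the lowering seen with trifluoromethyl and chloro, both on a different ring, to the fused part of the core of compound 1. Nothing available explains the step. Open, from the compounds shown here alone, is whether a methoxy group or an amine at this same position would give a similar step, and whether hydroxy elsewhere on this ring would match it.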